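A few compounds are considered here, and "the series" means these few. Any claim that something is new, unique, unknown or untested is made for them only; others in the source may bear on it.

Working notes on the series

For the measured compounds named here, compound 2 `C=C(Br)C(=O)Nc1cccc(-c2cn3nc(-c4ccc(F)cc4)sc3n2)c1` gives the lowest number of the three so far measured. In a functional assay on HeLa cells (Homo sapiens) for inhibition, read by cell counting, with a stated time of 4 days (on this read-out lower numbers stand for stronger inhibition and higher numbers for weaker inhibition), compound 2 gives 870 nM. Compound 1 `C=C(Br)C(=O)Nc1cccc(-c2cn3nc(-c4ccc(CC)cc4)sc3n2)c1` gives 3200 nM in this assay, and compound 3 `CCOc1ccc(-c2nn3cc(-c4cccc(N)c4)nc3s2)cc1`, which carries the free aniline in place of the bromoacrylamide, gives 94000 nM in this assay. Going by the values given here, the one single-point step in the set is a 3.7-fold lower number from compound 1 to compound 2 (0.57 log units; beyond the scatter), a change on the aromatic carbon of the five-membered ring that bears the pendant aryl group.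

Compound 4 `C=C(Br)C(=O)Nc1cccc(-c2cn3nc(Cc4cccc(OC)c4)sc3n2)c1` is not yet measured. It differs from compound 2 by 3-methoxybenzyl in place of 4-fluorophenyl on an aromatic carbon. Among the compounds with values here, this is a larger alteration than the one measured step, since both the substituent and the link to the ring change, and no measured pair covers a benzyl group at this position. Within the data shown here, the only step that bears on the site, from ethyl to fluoro, favoured the fluoro compound; moving away from fluoro to a 3-methoxybenzyl group is therefore expected to give a weaker result, with wide uncertainty.

For compound 4 the expected value in this assay is 3000 nM, within a range of 800 nM to 12000 nM. The expected step is a 3.4-fold higher number from compound 2 to compound 4 (0.54 log units; beyond the scatter).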

Compound 4, half-maximal inhibitory concentration: 2500 nM
Compound 4: middle estimate off by 1.2-fold (0.08 log units), on the high side, and the stated range covers the measured number.
By their numbers in this assay, from the lowest: compound 2; then compounds 4 and 1 (each within the scatter of the next); then compound 3.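

In this assay, the position on the five-membered ring accepts 3-methoxybenzyl in place of 4-fluorophenyl with only a modest loss, shown by a 2.9-fold higher number from compound 2 to compound 4 (0.46 log units; beyond the scatter). Against the 4-ethylphenyl group, the same entering group gives a 1.3-fold lower number from compound 1 to compound 4 (0.11 log units; within the scatter), so 3-methoxybenzyl and 4-ethylphenyl cannot be told apart at this position, while among the three compounds with the same bromoacrylamide side, compounds 1, 2 and 4, the 4-fluorophenyl group of compound 2 alone stands apart, with both of its steps beyond the scatter. No measured information is at hand to explain why these three groups rank as they do.

Still open, from the compounds shown here alone, is how much of the step to compound 4 belongs to the methoxy group and how much to the carbon link, a question that plain benzyl or 4-fluorobenzyl at this position would address. Also open, going by these compounds, is whether the position accepts groups of another kind, such as an amine, a carboxylic acid or a longer alkyl chain, and whether the preference for 4-fluorophenyl holds with other halogens, such as chloro, on the same ring.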